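The compounds below may be only part of what the source reports. "The series", "measured", "known", "first", "only" and "open" are said of these compounds alone.

Measured so far:
compound 1 `CN(C)C1(C)CN(c2c(F)cc3c(=O)c(C(=O)O)cn(C4CC4)c3c2F)C1` — in a physicochemical assay for solubility, at pH 7.4 (a higher number here means a more soluble compound, a lower number a less soluble compound), compound 1 gives 23.6 ug/mL
compound 2 `C[C@H]1[C@@H](N)CN1c1c(F)cc2c(=O)c(C(=O)O)cn(C3CC3)c2c1F` — in this assay compound 2 gives 23.6 ug/mL

For the measured compounds named here, compound 2 stands level with compound 1 in this assay; the only measured step, no change at the digits printed from compound 1 to compound 2 (within the scatter), lies within the scatter. Compound 3 `C[C@H]1[C@@H](N)CN1c1cc2c(cc1F)c(=O)c(C(=O)O)cn2C1CC1` is not yet measured. It differs from compound 2 by hydrogen in place of fluoro on an aromatic carbon. Going by the values given here, no measured step exchanges fluoro for hydrogen on the shared core, so nothing here bears directly on this change; the single measured step shows only that one substituent swap left this assay level. Among the compounds with values here, with no bearing step, the expected step of a 1.1-fold higher number from compound 2 to compound 3 (0.03 log units; within the scatter) is none beyond the scatter. Compound 3 is therefore estimated at 25 ug/mL, within 10 ug/mL to 60 ug/mL.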

Compound 3, solubility: 6.1 ug/mL
Beside the measured number, compound 3's estimate is 4.1-fold (0.61 log units) above it, outside the stated range (below it).
By their numbers in this assay, from the lowest: compound 3; then compounds 1 and 2 (each within the scatter of the next).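

In this assay, for the compounds shown here, this is the first single change to move the number beyond the scatter: with hydrogen in place of fluoro on the aromatic carbon ortho to a fused ring, the series shows a 3.9-fold lower number from compound 2 to compound 3 (0.59 log units; beyond the scatter). The fluoro at this position therefore matters to the read-out here, whereas the earlier swap of the group of 8 heavy atoms left it level. Nothing measured explains the drop.

On these data alone, whether chloro or methoxy at this position would stay level with compound 2 remains open. So does whether the same exchange would give a similar step with the group of 8 heavy atoms of compound 1.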